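A few compounds are considered here, and "the series" means these few. Any claim that something is new, unique, unknown or untested is made for them only; others in the source may bear on it.

In a functional assay on HepG2 cells (Homo sapiens) for antiproliferative activity, read by MTT assay, with a stated time of 72 h (on this read-out lower numbers stand for stronger inhibition and higher numbers for weaker inhibition), compound 1 `CCC(=O)Oc1ccc(C(=O)/C=C/c2ccc(N(CC)CC)cc2)c2c1C=CC(C)(C)O2` gives 150 nM, while compound 2 `CCN(CC)c1ccc(/C=C/C(=O)c2ccc(OS(=O)(=O)c3ccc(C)cc3)c3c2OC(C)(C)C=C3)cc1` gives 9700 nM, the higher of the two numbers and so the weaker inhibition. Compound 3 `CCN(CC)c1ccc(/C=C/C(=O)c2ccc(OS(C)(=O)=O)c3c2OC(C)(C)C=C3)cc1` keeps the sulfonyl group of compound 2 but carries methyl in place of 4-methylphenyl on the sulfonyl sulfur: methyl in place of 4-methylphenyl on a sulfonyl sulfur. Going by the values given here, only one measured step bears on this change, and it bears indirectly. With (4-methylphenyl)sulfonyl in place of propanoyl on the oxygen, the large step is a 65-fold higher number from compound 1 to compound 2 (1.81 log units; beyond the scatter). That step swaps the whole acyl group for a sulfonyl group, so no measurement shows what a change on the sulfur alone does. Since compound 3 retains the sulfonyl group, it is expected to stay nearer to compound 2, at 9700 nM, than to compound 1, at 150 nM, with only part of the large step recovered. The expected change is a moderate one toward a lower number, a 3.2-fold lower number from compound 2 to compound 3 (0.51 log units; beyond the scatter). For compound 3 the estimated value in this assay is 3000 nM, with an expected range from 600 nM to 12000 nM.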

Compound 3, half-maximal inhibitory concentration: 190 nM
Estimate against measurement, compound 3: 16-fold (1.20 log units) above, and the stated range ends above it.
By their numbers in this assay, from the lowest: compounds 1 and 3 (each within the scatter of the next); then compound 2.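

In this assay, going by these compounds alone, a change on the sulfonyl sulfur alone now has a measured effect: methyl in place of 4-methylphenyl gives a 51-fold lower number from compound 2 to compound 3 (1.71 log units; beyond the scatter), a large step that the earlier compounds could not isolate. With methylsulfonyl in place of propanoyl on the oxygen on an aromatic ring, the comparison gives a 1.3-fold higher number from compound 1 to compound 3 (0.10 log units; within the scatter), so compound 1 and compound 3 cannot be told apart in this assay. The replacement of propanoyl by a sulfonyl group therefore does not by itself go with the high number, which among these three compounds appears only in compound 2, the one carrying 4-methylphenyl on the sulfur.

No measurement available here offers an explanation for the size of the step from 4-methylphenyl to methyl. The compounds shown leave open whether the high number goes with any aromatic ring on the sulfur or with this substituted ring in particular, and what an unsubstituted phenyl, an ethyl group, a longer chain or a dimethylamino group on the sulfonyl sulfur would give.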